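Methoxy for Hydrogen on the Shared Core of Compound 1

This account rests on a few compounds, and the source may have more. Where it says the series, first, only, none or still open, it means among the compounds named here.

Compound 1, `CN(C)C(=O)N1Cc2ccccc2C(c2cccc(O)c2)C1`, in a functional assay on A2780 cells (Homo sapiens) for antiproliferative activity (a higher number here means a weaker inhibitor, a lower number a stronger inhibitor), stands as "not determined" (no result reported), so no single number for it was reported. The only measured point in this series comes from compound 2, `CN(C)C(=O)N1Cc2cc(Br)ccc2C(c2cccc(O)c2)C1`, which carries a bromine on the same fused ring system and in this assay gives 879 nM. Compound 1 therefore stands without a value of its own, and compound 2 offers the lone anchor for what this core can do.

Compound 3, `COc1cccc2c1CN(C(=O)N(C)C)CC2c1cccc(O)c1`, is obtained from compound 1 by the change (methoxy in place of hydrogen on an aromatic carbon). No measured pair shows the effect of this change, so the size of the step in this assay is open; a shift within the usual scatter in either direction seems the most defensible expectation, with no strong reason to expect a large gain or loss.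

Taking the value of compound 2 as the nearest guide, compound 3 is expected to give about 1000 nM in this assay, with a likely range from 300 nM to 3500 nM.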

Compound 3, half-maximal inhibitory concentration: 332 nM
The estimate for compound 3 lay 3.0-fold (0.48 log units) above the measured number; low and high end bracket the measured number.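

In this assay, going by these compounds alone, compound 3 gives 332 nM, but compound 1 has no number to set against it, so no step from compound 1 to compound 3 can be read. From the compounds shown here alone, what methoxy in place of hydrogen does to activity on the shared core therefore stays open. Nothing at hand offers an explanation for the value of compound 3.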